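The compounds below may be only part of what the source reports. "The series", "measured", "known", "first", "only" and "open" are said of these compounds alone.

In a functional assay on A549 cells (Homo sapiens) for inhibition, with a stated time of 72 h (on this read-out lower numbers stand for stronger inhibition and higher numbers for weaker inhibition), compound 3 `COc1ccc(C2Cc3ccccc3C(C3=C(O)OC(C)(c4ccccc4)CC3=O)C2)cc1` reaches only a limit of the assay, > 10000 nM. Compound 2 `CC1(c2ccccc2)CC(=O)C(C2CC(c3ccc(OCc4ccc(C(F)(F)F)cc4)cc3)Cc3ccccc32)=C(O)O1` also gives only a limit in this assay, > 10000 nM. The step that the two limits leave unreadable from compound 2 to compound 3 therefore cannot be read, as both ends sit at the limit of > 10000 nM in this assay, at which 2 of the 3 values shown sit. For the measured compounds named here, compound 1 `CCC1(c2ccccc2)CC(=O)C(C(CC(=O)c2ccc(-c3ccc(Br)cc3)cc2)c2ccccc2)=C(O)O1` gives 8130 nM in this assay and is the only compound with a number rather than a limit. Compound 4 `CCC1(c2ccccc2)CC(=O)C(C2CC(c3ccc(OC)cc3)Cc3ccccc32)=C(O)O1` differs from compound 3 by methyl in place of hydrogen on a saturated chain carbon bound to a saturated ring carbon. Going by the values given here, no measured step covers this kind of change, so no size or direction can be taken from the data. The step that the limit leaves unreadable from compound 3 to compound 4 is expected to be small, leaving compound 4 at or near the limit. For compound 4 the estimated value is 12000 nM, with a range from 5000 nM to 30000 nM.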

Compound 4, half-maximal inhibitory concentration: > 10000 nM
Compound 4: no number, only a limit; the forecaster's own chance of this, stated with the estimate: 70%; the middle value lies beyond the limit too.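

Compound 3 and compound 4 both stop at a limit of the assay, so the step between them cannot be read: the limit of > 10000 nM in this assay, at which 3 of the 4 values shown sit.

The compounds shown leave open whether methyl in place of hydrogen on this saturated chain carbon changes the result in this assay at all.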